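The source may report more compounds than this note shows. Statements on the series, on what has been measured and on what is new or still open speak of the compounds shown alone.

Among the measured compounds shown here, compound 2 `CC(C)(C)c1ccc(-c2cc(N3CCC(CCNS(N)(=O)=O)CC3)ncn2)cc1` holds the only number of the series: in a functional assay on M21 cells (Homo sapiens) for antiproliferative activity, read by sulforhodamine B assay, with a stated time of 48 h (a lower number here means a stronger inhibitor of growth, a higher number a weaker inhibitor of growth), compound 2 gives 18400 nM. Compound 1 `NS(=O)(=O)NCCC1CCN(c2cc(-c3ccccc3)ncn2)CC1` reports only a limit in this assay, namely > 100000 nM. For the measured compounds named here, the single measured step, an at least 5.4-fold lower number from compound 1 to compound 2 (0.73 log units; beyond the scatter), is anchored on that limit of > 100000 nM in this assay, at which 1 of the 2 values shown sits, and therefore marks only the least gain that tert-butyl brought over hydrogen. Compound 3 `COc1ccc(-c2cc(N3CCC(CCNS(N)(=O)=O)CC3)ncn2)cc1` differs from compound 2 by methoxy in place of tert-butyl on an aromatic carbon. The change removes the tert-butyl that carried compound 2 off the limit and puts in a smaller methoxy, so it runs back toward the measured step. Because an at least 5.4-fold lower number from compound 1 to compound 2 (0.73 log units; beyond the scatter) was at least modest, compound 3 is expected to fall between the two measured points, with a loss beyond the scatter. The step of a 2.7-fold higher number from compound 2 to compound 3 (0.43 log units; beyond the scatter) is the expected size. Compound 3 is estimated at 50000 nM, ranging from 15000 nM to 150000 nM, with a fair chance that this assay again returns only a limit.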

Compound 3, concentration for 50% growth inhibition: 69800 nM
Beside the measured number, compound 3's estimate is 1.4-fold (0.14 log units) below it; the range from low to high includes it.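

In this assay, methoxy in place of tert-butyl on the aromatic carbon para to a large group gives a 3.8-fold higher number from compound 2 to compound 3 (0.58 log units; beyond the scatter), a modest step that now separates two substituents from each other, not only a substituent from hydrogen. Between these two groups, the lower number at this position goes with tert-butyl, so the value of compound 2 is not matched by methoxy there. For methoxy in place of hydrogen, the data give an at least 1.4-fold lower number from compound 1 to compound 3 (0.15 log units; that floor lies within the scatter). Whether methoxy gives any gain over hydrogen cannot be read, because compound 1 reports only a limit and the resulting floor stays within the scatter: the limit of > 100000 nM in this assay, at which 1 of the 3 values shown sits.

The pair cannot tell whether the step follows the heavy-atom count or the hydrogen-bond acceptor that methoxy brings, since the two groups differ in both. From the compounds shown here alone, how an amine, a carboxylic acid or a longer alkyl chain at this position would compare with compound 2 at 18400 nM remains open.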